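The source may hold more compounds than are shown below. What is called first, only, known or untested is meant among the compounds shown, and "the series" means these compounds.

Measured so far in a functional assay (spleen, spleen) for activation, with Mus musculus as the target; on this read-out higher numbers stand for an effect only at larger amounts of compound and lower numbers for an effect already at smaller amounts:
- compound 1, `Nc1nc(O)nc2c1nc(O)n2Cc1ccccc1`: 0.1 uM
- compound 2, `CCCSc1nc(N)c2nc(O)n(Cc3ccccc3)c2n1`: 0.01 uM
- compound 3, `CCCCCNc1nc(N)c2nc(O)n(Cc3ccccc3)c2n1`: 0.1 uM

Compound 3 carries a pentylamino group where compound 1 carries hydroxy and compound 2 carries propylsulfanyl. In this assay compound 3 stands level with compound 1 at the digits shown, the two together being the highest numbers of the three; the remaining gap is a 10-fold higher number from compound 2 to compound 3 (1.00 log units; beyond the scatter).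

Compound 4, `CCOc1nc(N)c2nc(O)n(Cc3ccccc3)c2n1`, is not yet measured. It differs from compound 3 only in one place: ethoxy in place of pentylamino on an aromatic carbon.

Steps that bear on this exchange are a 10-fold lower number from compound 1 to compound 2 (1.00 log units; beyond the scatter), no change at the digits printed from compound 1 to compound 3 (within the scatter) and a 10-fold higher number from compound 2 to compound 3 (1.00 log units; beyond the scatter). Among the compounds with values here, neither of these involves an ethoxy group, so no measured step maps onto it directly. The substituent in compound 4 is, like propylsulfanyl in compound 2, a short chain attached through a heteroatom without a hydrogen-bond donor, which suggests a number somewhere between those of compound 2 and compound 3. The expectation is therefore a lowering of modest size, a 3.3-fold lower number from compound 3 to compound 4 (0.52 log units; beyond the scatter), with a wide margin.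

Compound 4 is estimated at 0.03 uM in this assay, expected to fall within 0.005 uM to 0.2 uM.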

Compound 4, minimum effective concentration: 0.1 uM
The estimate for compound 4 lay 3.3-fold (0.52 log units) below the measured number; the range from low to high includes it.
By their numbers in this assay, from the lowest: compound 2; then compounds 1, 3 and 4 (each within the scatter of the next).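

Replacing pentylamino with ethoxy in this assay gives no change at the digits printed from compound 3 to compound 4 (within the scatter), so this position tolerates the change from 6 heavy atoms to 3 and from 1 hydrogen-bond donor to 0 without a shift beyond the scatter. Having no donor on the substituent is therefore not enough to give the low number of compound 2, as the ethoxy compound shows (a 10-fold higher number from compound 2 to compound 4 (1.00 log units; beyond the scatter)). Placing ethyl on the oxygen also leaves compound 4 level with the hydroxy compound (no change at the digits printed from compound 1 to compound 4 (within the scatter)), so among these four substituents only propylsulfanyl stands apart.

No evidence on the origin of these differences is available. From the compounds shown here alone, whether the low number of compound 2 follows its sulfur link or its longer chain remains open, and propoxy and ethylsulfanyl groups at this position would separate the two.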